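Replacing pyrrolidin-1-yl with 4-acetylpiperazin-1-yl: working notes

A few compounds are considered here, and "the series" means these few. Any claim that something is new, unique, unknown or untested is made for them only; others in the source may bear on it.

In a functional assay on the whole organism for inhibition, with Meriones unguiculatus as the target, with a stated time of 1 h (on this read-out lower numbers stand for an effect already at smaller amounts and higher numbers for an effect only at larger amounts of compound), compound 1 `Cc1cc(F)ccc1[C@H]1C[C@@H](N(C)C)CCN1C(=O)N(C)Cc1cc(C(F)(F)F)cc(C(F)(F)F)c1` gives 0.26 mg/kg and compound 2 `Cc1cc(F)ccc1[C@H]1C[C@@H](N2CCCC2)CCN1C(=O)N(C)Cc1cc(C(F)(F)F)cc(C(F)(F)F)c1` gives 0.3 mg/kg, so the two values lie within the scatter of each other. Compound 3 `CC(=O)N1CCN([C@H]2CCN(C(=O)N(C)Cc3cc(C(F)(F)F)cc(C(F)(F)F)c3)[C@@H](c3ccc(F)cc3C)C2)CC1` carries 4-acetylpiperazin-1-yl in place of pyrrolidin-1-yl on a saturated ring carbon. Going by the values given here, the only measured step at this place is a 1.2-fold higher number from compound 1 to compound 2 (0.06 log units; within the scatter), and no measured compound carries the entering group, so the evidence is thin. The expected step is a 1.5-fold lower number from compound 2 to compound 3 (0.18 log units; within the scatter), with no change expected beyond the scatter. For compound 3 the estimated value is 0.2 mg/kg, with an expected range of 0.06 mg/kg to 0.7 mg/kg.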

Compound 3, dose for 50% inhibition: 0.09 mg/kg
Compound 3: the middle estimate sits 2.2-fold (0.35 log units) above what was measured; the measured number falls inside the stated range.
By their numbers in this assay, from the lowest: compound 3; then compounds 1 and 2 (each within the scatter of the next).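

Going by these compounds alone, the position now separates groups for the first time: in this assay 4-acetylpiperazin-1-yl in place of pyrrolidin-1-yl gives a clear step (a 3.3-fold lower number from compound 2 to compound 3 (0.52 log units; beyond the scatter)), and the step from dimethylamino is also beyond the scatter (a 2.9-fold lower number from compound 1 to compound 3 (0.46 log units; beyond the scatter)). Dimethylamino and pyrrolidin-1-yl alone gave no such separation, and the larger group is accepted at this place on a saturated ring carbon. No measured data bear on what lies behind this change.

As far as these compounds go, it remains open whether the acetyl group or the piperazine ring carries the step. Unsubstituted piperazine and morpholine would separate these two parts.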